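Halogen swap on the sulfonyl ring: compound 3 to compound 4

The source may report more compounds than this note shows. Statements on the series, on what has been measured and on what is new or still open speak of the compounds shown alone.

Measured so far:
compound 1, `O=C(/C=C/c1ccccc1)NS(=O)(=O)c1ccc(Br)cc1`, in a functional assay on B16-F10 cells (Mus musculus) for antiproliferative activity, read by ELISA and MTT assay, with a stated time of 48 h (on this read-out higher numbers stand for weaker inhibition and lower numbers for stronger inhibition), compound 1 gives 3.9 ug/mL
compound 2, `O=C(/C=C/c1ccc(F)cc1)NS(=O)(=O)c1ccc(Br)cc1`, in this assay compound 2 gives 2.8 ug/mL
compound 3, `O=C(/C=C/c1ccc(Br)cc1)NS(=O)(=O)c1ccc(F)cc1`, in this assay compound 3 gives 1.2 ug/mL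

Compound 3 holds the lowest number of the three in this assay, its steps to compound 2 and to compound 1 both beyond the scatter. Within the data shown here, the one single-place step in the set, a 1.4-fold lower number from compound 1 to compound 2 (0.14 log units; within the scatter), touches the cinnamoyl ring, not the sulfonyl ring, and is within the scatter. Compound 2 and compound 3 differ in more than one place, so their values show only that the halogen arrangement of compound 3 gives the lower number.

Compound 4, `O=C(/C=C/c1ccc(Br)cc1)NS(=O)(=O)c1ccc(Br)cc1`, differs from compound 3 by bromo in place of fluoro on an aromatic carbon, that is 4-fluorophenyl to 4-bromophenyl on the sulfonyl side. Among the measured compounds shown here, no measured step bears on this exact change. For the measured compounds named here, the only available step on a halogen is within the scatter, so the expectation is a small step, a 1.5-fold higher number from compound 3 to compound 4 (0.18 log units; within the scatter), likely within the scatter. Compound 4 is estimated at 1.8 ug/mL, with a range from 0.8 ug/mL to 4 ug/mL.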

Compound 4, half-maximal inhibitory concentration: 5.1 ug/mL
Compound 4: middle estimate off by 2.8-fold (0.45 log units), on the low side; the whole stated range lies below it.
By their numbers in this assay, from the lowest: compound 3; then compounds 2, 1 and 4 (each within the scatter of the next).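

Bromo in place of fluoro on the sulfonyl ring gives the first single-place halogen step beyond the scatter (a 4.3-fold higher number from compound 3 to compound 4 (0.63 log units; beyond the scatter)), so this position distinguishes 4-fluorophenyl from 4-bromophenyl. With 4-bromophenyl held on the sulfonyl side, changes on the cinnamoyl ring stay within the scatter, both from fluoro (a 1.8-fold higher number from compound 2 to compound 4 (0.26 log units; within the scatter)) and from hydrogen (a 1.3-fold higher number from compound 1 to compound 4 (0.12 log units; within the scatter)), so in these compounds that ring does not separate hydrogen, fluoro and bromo. Nothing at hand explains this difference between the two rings.

Among these compounds, compound 3 is the only compound here with 4-fluorophenyl on the sulfonyl side, so it remains open whether the lower number holds with hydrogen or fluoro on the cinnamoyl ring. Also open, on these data alone, is how chloro, methoxy or an amine would read at the sulfonyl position.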